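Aryl variation on the thiourea nitrogen: cytotoxicity notes

A few compounds are considered here, and "the series" means these few. Any claim that something is new, unique, unknown or untested is made for them only; others in the source may bear on it.

The series keeps one shared core and varies the aryl group on one thiourea nitrogen. In an ADME assay on Huh-7 cells (Homo sapiens) for cytotoxicity (on this read-out lower numbers stand for higher toxicity in this test and higher numbers for lower toxicity in this test), compound 1 `NC(=S)Nc1cccc(OCCCCCCCCNC(=S)Nc2cc(Cl)cc(Cl)c2)c1` gives 12000 nM, compound 2 `NC(=S)Nc1cccc(OCCCCCCCCNC(=S)Nc2ccc(Br)cc2)c1` gives 18000 nM, and compound 3 `NC(=S)Nc1cccc(OCCCCCCCCNC(=S)Nc2ccccc2Br)c1` gives 36000 nM. On these numbers compound 3 stands highest of the three: the step of a 3.0-fold higher number from compound 1 to compound 3 (0.48 log units; beyond the scatter) lies beyond the scatter, while the step of a 2.0-fold higher number from compound 2 to compound 3 (0.30 log units; within the scatter) does not.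

Compound 4 `NC(=S)Nc1cccc(OCCCCCCCCNC(=S)Nc2ccc3[nH]ccc3c2)c1` follows from compound 3 by the change (1H-indol-5-yl in place of 2-bromophenyl on an amide-type nitrogen). For the measured compounds named here, the three measured steps at this position, a 1.5-fold higher number from compound 1 to compound 2 (0.18 log units; within the scatter), a 3.0-fold higher number from compound 1 to compound 3 (0.48 log units; beyond the scatter) and a 2.0-fold higher number from compound 2 to compound 3 (0.30 log units; within the scatter), all stayed modest, and none of them involves a fused bicyclic group, so the indolyl case has no close precedent here. Given that every aryl swap so far shifted this assay only modestly, the expected step of a 1.3-fold lower number from compound 3 to compound 4 (0.11 log units; within the scatter) is small, most likely within the scatter, with no clear direction. Compound 4 is therefore estimated at 28000 nM, with a range from 10000 nM to 80000 nM.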

Compound 4, half-maximal cytotoxic concentration: 18000 nM
Estimate against measurement, compound 4: 1.6-fold (0.19 log units) above; the range from low to high includes it.
By their numbers in this assay, from the lowest: compounds 1, 2, 4 and 3 (each within the scatter of the next, the first and the last beyond it).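

In this assay, for the compounds shown here, the first fused bicyclic group at this position, 1H-indol-5-yl on the amide-type nitrogen, stays within the scatter of all three phenyl compounds (a 2.0-fold lower number from compound 3 to compound 4 (0.30 log units; within the scatter); no change at the digits printed from compound 2 to compound 4 (within the scatter); a 1.5-fold higher number from compound 1 to compound 4 (0.18 log units; within the scatter)). The change from 2-bromophenyl adds a five-membered aromatic ring and a hydrogen-bond donor and removes the bromine, yet this read-out does not separate compound 4 from any other compound in the set. No measurement at hand accounts for this result.

Still open, on these data alone, is whether an aryl group carrying an amine or a carboxylic acid would move this read-out beyond the scatter. The same question applies to a cyclohexyl group in place of the aryl group.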